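The source may hold more compounds than are shown below. What is called first, only, known or untested is meant among the compounds shown, and "the series" means these compounds.

Measured so far in a functional assay on HeLa cells (Homo sapiens) for cytotoxicity, read by MTT assay, with a stated time of 2 days, tested at 100 uM; a lower number here means a stronger effect, a higher number a weaker effect of the compound at the concentration tested:
compound 1, `CC(=O)c1cc(-c2ccc(F)cc2)cc2cc(-c3ccccc3)[nH]c12`, gives 24.8%;
compound 2, `COc1ccc(-c2cc(C(C)=O)c3[nH]c(-c4ccccc4)cc3c2)cc1`, gives 21.1%;
compound 3, `CC(=O)c1cc(-c2ccccc2)cc2cc(-c3ccc(F)cc3)[nH]c12`, gives 68.3%.

Compound 1 and compound 2 differ in a single place: methoxy in place of fluoro on an aromatic carbon. That change produced a number 3.7 percentage points lower from compound 1 to compound 2 (within the scatter), so the two values read alike. Compound 3 is built from the same atoms as compound 1, joined differently; the difference between the two cores is not broken down here. In this assay compound 3 stands clearly higher than compound 1 and compound 2.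

Compound 4, `COc1ccc(-c2cc3cc(-c4ccccc4)cc(C(C)=O)c3[nH]2)cc1`, has not been measured. It differs from compound 3 by the same change: methoxy in place of fluoro on an aromatic carbon. Because a number 3.7 percentage points lower from compound 1 to compound 2 (within the scatter) lay within the scatter, a similarly small step is expected here, a number 3.3 percentage points lower from compound 3 to compound 4 (within the scatter). Compound 4 is therefore estimated to give 65% in this assay, expected to fall between 50% and 80%.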

Compound 4, a percentage reported as activity, at one concentration (the size of the read-out at that concentration, not a potency): 32.8%
Beside the measured number, compound 4's estimate is 32.2 percentage points above it, and the stated range ends above it.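

In this assay, replacing 4-fluorophenyl with 4-methoxyphenyl gave a number 35.5 percentage points lower from compound 3 to compound 4 (beyond the scatter). The same change therefore had a different size on the two cores: the same change on two cores in this assay, a number 3.7 percentage points lower (within the scatter) from compound 1 to compound 2 and a number 35.5 percentage points lower (beyond the scatter) from compound 3 to compound 4, 31.8 percentage points apart, beyond the scatter of two such steps

This shows that a step measured on one core could not be carried over to the other in these two pairs, but two pairs give no general rule for the series and do not explain the difference.

The compounds shown carry only fluoro or methoxy at this position, which leaves open how an amine, a carboxylic acid or a longer chain there would read in this assay. Going by these compounds, whether either core's step is the more typical one also stays open.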